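Swapping chloro for hydrogen on the aryl ring of compound 2

The compounds below may be only part of what the source reports. "The series", "measured", "known", "first", "only" and "open" are said of these compounds alone.

Compound 2 `COC(=O)/C(=C/c1ccccc1)CN1C(=O)[C@@H](OC)[C@H]1c1ccc(Cl)cc1` was tested in a functional assay on MCF7 cells (Homo sapiens) for antiproliferative activity, read by MTT assay, with a stated time of 48 h (a lower number here means a stronger inhibitor, a higher number a weaker inhibitor), where compound 2 gives 15300 nM. Among the three numbers it stands second highest: compound 1 `CCOC(=O)/C(=C/c1ccccc1)CN1C(=O)[C@@H](OC)[C@H]1c1ccc(Cl)cc1` gives 12700 nM, and the step of a 1.2-fold higher number from compound 1 to compound 2 (0.08 log units; within the scatter) lies within the scatter, while compound 3 `CO[C@@H]1C(=O)N(C/C(C#N)=C/c2ccccc2)[C@@H]1c1ccc(Cl)cc1Cl` gives 31900 nM, a number beyond the scatter from compound 2. Compound 4 `COC(=O)/C(=C/c1ccccc1)CN1C(=O)[C@@H](OC)[C@H]1c1ccccc1` differs from compound 2 by hydrogen in place of chloro on an aromatic carbon. Going by the values given here, no measured step bears on this change: the single known step concerns a different place, and compound 3 differs from compound 2 in more than one place, so its value alone cannot guide. For compound 4 the expected step is a 1.3-fold higher number from compound 2 to compound 4 (0.12 log units; within the scatter), judged small and uncertain in direction. The estimate for compound 4 is 20000 nM, with a range from 8000 nM to 50000 nM.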

Compound 4, half-maximal inhibitory concentration: 12900 nM
For compound 4 the middle estimate is 1.6-fold (0.19 log units) above the measured one, within the range that was stated.
By their numbers in this assay, from the lowest: compounds 1, 4 and 2 (each within the scatter of the next); then compound 3.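

Going from 4-chlorophenyl to phenyl gives a 1.2-fold lower number from compound 2 to compound 4 (0.07 log units; within the scatter) in this assay. Going by these compounds alone, at this place on the ring, para to a large group, the chloro group can therefore give way to hydrogen without a step beyond the scatter, and this is the first measured step at this position. No supporting data explain this outcome. As far as these compounds go, it remains open whether a methoxy group, an amine or a carboxylic acid at this position would give a step beyond the scatter, and whether the same change would read alike with the ester of compound 1.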